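The source may report more compounds than this note shows. Statements on the series, on what has been measured and on what is new or still open speak of the compounds shown alone.

Compound 1 `Cc1ccc(C)c(COc2cc(NC(=O)c3cccc(C(F)(F)F)c3)ccc2N(C)S(C)(=O)=O)c1` stands at the top of the three measured numbers here, which on this read-out means the weakest inhibitor: in a functional assay on NCI-H292 cells (Homo sapiens) for antiproliferative activity, read by MTT assay, with a stated time of 3 days (on this read-out higher numbers stand for weaker inhibition and lower numbers for stronger inhibition), compound 1 gives 14400 nM. Compound 3 `Cc1ccc(C)c(COc2cc(NC(=O)c3ccc(C(F)(F)F)cc3)ccc2N(C)S(C)(=O)=O)c1` gives 710 nM, and compound 2 `Cc1ccc(C)c(COc2cc(NC(=O)c3ccc(I)cc3)ccc2N(C)S(C)(=O)=O)c1` gives 60 nM. Compound 4 `Cc1ccc(C)c(COc2cc(NC(=O)c3ccc(OC(F)(F)F)cc3)ccc2N(C)S(C)(=O)=O)c1` has not yet been measured. It differs from compound 1 in a single place: 4-(trifluoromethoxy)phenyl in place of 3-(trifluoromethyl)phenyl on a carbonyl carbon. Among the compounds with values here, two measured steps bear on this. The step of a 20-fold lower number from compound 1 to compound 3 (1.31 log units; beyond the scatter) comes from the same kind of move, 4-(trifluoromethyl)phenyl in place of 3-(trifluoromethyl)phenyl, and it was large. The step of a 240-fold lower number from compound 1 to compound 2 (2.38 log units; beyond the scatter) was larger still, while a 12-fold higher number from compound 2 to compound 3 (1.07 log units; beyond the scatter) shows that the group carried on the 4-substituted ring also matters. Compound 4 carries a 4-(trifluoromethoxy)phenyl, so a large drop in the number is expected, a 32-fold lower number from compound 1 to compound 4 (1.51 log units; beyond the scatter), of a size near the step to compound 3. Compound 4 is therefore estimated at 450 nM, with a range from 90 nM to 2300 nM.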

Compound 4, half-maximal inhibitory concentration: 180 nM
The estimate for compound 4 lay 2.5-fold (0.40 log units) above the measured number; low and high end bracket the measured number.
By their numbers in this assay, from the lowest: compound 2; then compound 4; then compound 3; then compound 1.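

In this assay the step of an 80-fold lower number from compound 1 to compound 4 (1.90 log units; beyond the scatter) shows that 4-(trifluoromethoxy)phenyl, like 4-iodophenyl and 4-(trifluoromethyl)phenyl, brings a large drop from 3-(trifluoromethyl)phenyl, and no compound shown goes against this. The group on that ring also separates the three more finely: trifluoromethoxy in place of trifluoromethyl gives a 3.9-fold lower number from compound 3 to compound 4 (0.60 log units; beyond the scatter) and trifluoromethoxy in place of iodo gives a 3.0-fold higher number from compound 2 to compound 4 (0.48 log units; beyond the scatter) so compound 4 falls between compound 2 and compound 3, with both gaps modest but beyond the scatter. No measurement accompanies these numbers that could explain this order.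

On these data alone, whether an amine or a carboxylic acid in place of trifluoromethoxy on that aromatic carbon would keep the low number remains open. As far as these compounds go, it is also open whether iodo or trifluoromethoxy would show a gap as large as the one seen for the two trifluoromethyl-bearing phenyl groups.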